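Substituent swap on the amide-type nitrogen of compound 3

The source may report more compounds than this note shows. Statements on the series, on what has been measured and on what is new or still open speak of the compounds shown alone.

Compound 1 `CC(C)(C)C(=O)Nc1ccc(S(=O)(=O)Oc2ccccc2I)cc1` carries tert-butyl on the carbonyl carbon; in a functional assay on MCF7 cells (Homo sapiens) for antiproliferative activity, read by sulforhodamine B assay, with a stated time of 48 h (on this read-out lower numbers stand for stronger inhibition and higher numbers for weaker inhibition), compound 1 gives 6600 nM. Compound 2 `O=C(CCl)Nc1ccc(S(=O)(=O)Oc2ccccc2I)cc1` gives 2500 nM, and compound 3 `O=C(NCCCCl)Nc1ccc(S(=O)(=O)Oc2ccccc2I)cc1` gives 7600 nM. Compound 3 stands at the highest number of the three, but a 1.2-fold higher number from compound 1 to compound 3 (0.06 log units; within the scatter) is within the scatter, whereas a 3.0-fold higher number from compound 2 to compound 3 (0.48 log units; beyond the scatter) and a 2.6-fold lower number from compound 1 to compound 2 (0.42 log units; beyond the scatter) are beyond it.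

Compound 4 `O=C(Nc1ccc(S(=O)(=O)Oc2ccccc2I)cc1)NC1CC1` differs from compound 3 by cyclopropyl in place of 3-chloropropyl on an amide-type nitrogen. For the measured compounds named here, no measured step touches this nitrogen: the steps on record all change the group on the carbonyl carbon, and the widest of them, a 3.0-fold higher number from compound 2 to compound 3 (0.48 log units; beyond the scatter), is only modest. The change to compound 4 keeps the ((3-chloropropyl)carbamoyl)amino link as (cyclopropylcarbamoyl)amino and alters nothing else, so no step beyond the scatter in this assay is expected, with no clear direction. For compound 4 the expected value is 8000 nM, with a range of 3000 nM to 20000 nM. The estimated step is accordingly a 1.1-fold higher number from compound 3 to compound 4 (0.02 log units; within the scatter).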

Compound 4, half-maximal inhibitory concentration: 7400 nM
Compound 4: the middle estimate sits 1.1-fold (0.03 log units) above what was measured, within the range that was stated.
By their numbers in this assay, from the lowest: compound 2; then compounds 1, 4 and 3 (each within the scatter of the next).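

In this assay, for the compounds shown here, the first change on the amide-type nitrogen leaves the number in place (a 1.0-fold lower number from compound 3 to compound 4 (0.01 log units; within the scatter)), so 3-chloropropyl and cyclopropyl cannot be told apart at this position, and a chain bearing chlorine is not required to hold this level. Cyclopropylamino on the carbonyl carbon also cannot be told apart from tert-butyl (a 1.1-fold higher number from compound 1 to compound 4 (0.05 log units; within the scatter)), while the gap to chloromethyl remains (a 3.0-fold higher number from compound 2 to compound 4 (0.47 log units; beyond the scatter)), leaving compound 2 as the only one of the four set apart from the others. No measurement on hand bears on the reason for this result.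

As far as these compounds go, it remains open whether a longer chain, a cyclohexyl ring or a chain ending in an amine on this nitrogen would move the number. From the compounds shown here alone, it also remains open whether the lower number of compound 2 is specific to chloromethyl, which bromomethyl or methyl on the carbonyl carbon would test.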